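Triazole ethers on pancreatic cells: a positional chlorine swap

A few compounds are considered here, and "the series" means these few. Any claim that something is new, unique, unknown or untested is made for them only; others in the source may bear on it.

Measured so far:
- Compound 1 `Clc1ccc(Cn2cc(COc3ccccc3)nn2)cc1`: in an ADME assay on PANC-1 cells (Homo sapiens) for inhibition, read by MTT assay, with a stated time of 48 h (a lower number here means a stronger inhibitor of growth, a higher number a weaker inhibitor of growth), compound 1 gives > 100 ug/mL, which is a limit of the assay and not a number.
- Compound 2 `Clc1cccc(Cn2cc(COc3ccccc3)nn2)c1`: in this assay compound 2 gives > 100 ug/mL, again a limit.
- Compound 3 `Clc1ccc(Cn2cc(COc3ccc(Cl)cc3)nn2)cc1`: in this assay compound 3 gives > 100 ug/mL, also a limit.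

Going by these compounds, the change 3-chlorophenyl in place of 4-chlorophenyl on a saturated chain carbon bound to an aromatic nitrogen gave a step that the two limits leave unreadable from compound 1 to compound 2, so its size is unknown. The cores of compound 1 and compound 3 differ by chloro in place of hydrogen on an aromatic carbon. Compound 4 `Clc1ccc(OCc2cn(Cc3cccc(Cl)c3)nn2)cc1` is not yet measured; it arises from compound 3 by the same change, (3-chlorophenyl in place of 4-chlorophenyl on a saturated chain carbon bound to an aromatic nitrogen). Within the data shown here, every value so far sits at the limit of > 100 ug/mL in this assay, at which 3 of the 3 values shown sit. With no readable step for this change, the step that the limit leaves unreadable from compound 3 to compound 4 is estimated as small, because the limit of > 100 ug/mL in this assay, at which 3 of the 3 values shown sit, is where compound 1, compound 2 and compound 3 all stand. Compound 4 is expected to give 150 ug/mL in this assay, most likely again only a limit.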

Compound 4, concentration for 50% growth inhibition: > 100 ug/mL
Compound 4: only a limit was reported (the forecaster's own chance of this, stated with the estimate: 80%); the middle value lies beyond the limit too.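

The steps from compound 2 and compound 3 to compound 4 cannot be read, because all four compounds stand at one limit: the limit of > 100 ug/mL in this assay, at which 4 of the 4 values shown sit.

Left open is whether 3-chlorophenyl in place of 4-chlorophenyl changes growth inhibition at all in this assay.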